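Swapping Propyl for Hydroxymethyl in an Inactive Pair

The compounds below may be only part of what the source reports. "The series", "measured", "known", "first", "only" and "open" are said of these compounds alone.

Compound 1 `CCCc1cc(-c2cc(Br)ccc2OC)no1` was tested in a functional assay on BV-2 cells (Mus musculus) for inhibition, read by Griess assay, with a stated time of 24 h (a higher number here means a weaker inhibitor, a lower number a stronger inhibitor), and gives only a limit of the assay, > 200000 nM. Compound 2 `COc1ccc(Br)cc1-c1cc(CO)on1` differs from compound 1 by hydroxy in place of ethyl on a saturated chain carbon bound to an aromatic carbon, and in this assay compound 2 likewise gives only a limit of the assay, > 200000 nM. The step that the two limits leave unreadable from compound 1 to compound 2 cannot be read because of the limit of > 200000 nM in this assay, at which 3 of the 3 values shown sit. Compound 3 `C=CCc1ccc(O)c(-c2cc(CCC)on2)c1` rests on another core; the difference between the cores of compound 1 and compound 3 is not broken down here. In this assay compound 3 also gives only a limit of the assay, > 200000 nM. Compound 4 `C=CCc1ccc(O)c(-c2cc(CO)on2)c1` is not yet measured and differs from compound 3 by hydroxy in place of ethyl on a saturated chain carbon bound to an aromatic carbon, the same change, at the same place, as that from compound 1 to compound 2. Because (the limit of > 200000 nM in this assay, at which 3 of the 3 values shown sit), an unreadable step is expected here too, a step that the limit leaves unreadable from compound 3 to compound 4. Compound 4 is expected to give 300000 nM, most likely reported again only as a limit.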

Compound 4, half-maximal inhibitory concentration: > 200000 nM
Compound 4: no number, only a limit; the forecaster's own chance of this, stated with the estimate: 85%; the middle value is on the limit's open side.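

No step can be read from compound 3 to compound 4, because both give only a limit of the assay, not a number: (the limit of > 200000 nM in this assay, at which 4 of the 4 values shown sit). The compounds shown leave open whether propyl to hydroxymethyl changes inhibition at all.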